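Removing the pyridinyl ester: free hydroxyl on the cyclohexyl chain

The source may hold more compounds than are shown below. What is called first, only, known or untested is meant among the compounds shown, and "the series" means these compounds.

Compound 2 `O=C(OC1CCC(CN2CCN(c3cc(=O)c4cc(C(F)(F)F)cc([N+](=O)[O-])c4s3)CC2)CC1)c1ccncc1` is the less stable of the two measured compounds in an ADME assay on cells (Hepatocyte, Homo sapiens) for metabolic stability, with a stated time of 30 min; on this read-out lower numbers stand for a less stable compound and higher numbers for a more stable compound: compound 2 gives 1%, while compound 1 `O=C(OC1CCC(CN2CCN(c3cc(=O)c4cc(C(F)(F)F)cc([N+](=O)[O-])c4s3)CC2)CC1)c1ccccc1` gives 56.4%. For the measured compounds named here, the only measured step is a number 55.4 percentage points lower from compound 1 to compound 2 (beyond the scatter). Compound 3 `O=c1cc(N2CCN(CC3CCC(O)CC3)CC2)sc2c([N+](=O)[O-])cc(C(F)(F)F)cc12` differs from compound 2 by hydrogen in place of (pyridin-4-yl)carbonyl on an oxygen on a saturated carbon. No measured step removes this group outright, so the account rests on the one step shown: the group that now leaves is the very group whose entry brought the large fall from compound 1 to compound 2, and compound 1, which bears phenyl in its place, gives 56.4%. A rise beyond the scatter is therefore expected for compound 3, with a step of about a number 59 percentage points higher from compound 2 to compound 3 (beyond the scatter). Compound 3 is estimated to reach 60%, within a range of 25% to 90%.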

Compound 3, percent of the compound remaining: 72.7%
For compound 3 the middle estimate is 12.7 percentage points below the measured one; measured number inside the range.
By their numbers in this assay, from the lowest: compound 2; then compound 1; then compound 3.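

In this assay, removing the acyl group from this oxygen to leave a hydroxy brings a number 71.7 percentage points higher from compound 2 to compound 3 (beyond the scatter) and, set against the benzoyl ester, brings a number 16.3 percentage points higher from compound 1 to compound 3 (beyond the scatter) as well. For the compounds shown here, the position therefore accepts having no acyl group at all, and the hydroxy compound stands above both esters rather than merely level with the better one, whereas the earlier pair showed only that the ring on the carbonyl matters. No measurement at hand bears on why the number moves at this place.

Whether the gain belongs to the free hydroxy itself or simply to the loss of the ester stays open, since the compounds shown do not separate the two. A methyl ether, an amine or a carboxylic acid at this place would bear on that question, and an acetate ester would show how the number responds to a small acyl group on this oxygen.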